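The source may hold more compounds than are shown below. What is called first, only, known or untested is meant among the compounds shown, and "the series" means these compounds.

Of the compounds shown here, two have so far been measured in a functional assay on SNB-75 cells (Homo sapiens) for cytotoxicity, read by sulforhodamine B assay, with a stated time of 48 h; on this read-out higher numbers stand for weaker inhibition of growth and lower numbers for stronger inhibition of growth. Compound 1 `Cn1cccc1-c1cc(-c2ccc(Br)cc2)[nH]c(=O)c1C#N` gives 25700 nM, and compound 2 `COc1ccc(-c2cc(-c3cccs3)[nH]c(=O)c2C#N)cc1` gives 39800 nM; these two numbers lie within the scatter of each other, so neither stands apart from the other. Compound 3 `Cn1cccc1-c1cc(-c2ccc(Br)cc2)n(C(=S)Nc2ccc(F)cc2)c(=O)c1C#N` is compound 1 carrying (a group of 10 heavy atoms (7 carbon, 1 nitrogen, 1 fluorine, 1 sulfur; one six-membered aromatic ring of carbon only) in place of a hydrogen atom, on an aromatic nitrogen). Among the measured compounds shown here, no measured pair shows what such a change does in this setting, so the step from compound 1 to compound 3 has no precedent here. The expectation is a step of a 1.7-fold lower number from compound 1 to compound 3 (0.23 log units; within the scatter), modest and toward stronger inhibition of growth. Compound 3 is therefore estimated at 15000 nM, with a range from 4000 nM to 60000 nM.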

Compound 3, concentration for 50% growth inhibition: 38000 nM
Estimate against measurement, compound 3: 2.5-fold (0.40 log units) below, within the range that was stated.
By their numbers in this assay, from the lowest: compounds 1, 3 and 2 (each within the scatter of the next).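

In this assay, among the compounds shown here, the hydrogen on the aromatic nitrogen gives way to the group of 10 heavy atoms with a 1.5-fold higher number from compound 1 to compound 3 (0.17 log units; within the scatter) as the result, the first reading at this position. This nitrogen therefore accepts a large group, with its six-membered aromatic ring, without a change beyond the scatter. No measured property is available to explain this result. As far as these compounds go, whether a short chain ending in an amine, or a carboxylic acid, would behave alike on this nitrogen remains open. So does whether the same group would give a similar result on compound 2.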